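The source may report more compounds than this note shows. Statements on the series, on what has been measured and on what is new or still open speak of the compounds shown alone.

Measured so far:
compound 1, `N#Cc1ccc(C(=O)Nc2ccc3nc(NC(=O)C4CCCCC4)sc3c2)cc1`: 3.3 ug/mL
compound 2, `C=CCOC(=O)Nc1ccc2nc(NC(=O)C3CCCCC3)sc2c1`: 0.58 ug/mL
compound 3, `O=C(Nc1ccc2nc(NC(=O)C3CCC3)sc2c1)c1c(Cl)cccc1Cl`: 0.013 ug/mL

In a functional assay on WI-38 VA13 cells (Homo sapiens) for cytotoxicity (a lower number here means that less compound is needed, a higher number that more compound is needed for the effect), compound 3 gives the lowest of the three numbers, with compound 2 giving 0.58 ug/mL and compound 1 giving 3.3 ug/mL, both well above it. Compound 4, `O=C(Nc1ccc2nc(NCC3CCCCC3)sc2c1)c1c(Cl)cccc1Cl`, differs from compound 3 in one place: cyclohexylmethyl in place of cyclobutylcarbonyl on a nitrogen on an aromatic ring. For the measured compounds named here, the only measured step, a 5.7-fold lower number from compound 1 to compound 2 (0.76 log units; beyond the scatter), changes a different part of the shared core, so no measured step bears directly on this change. With the carbonyl of the cyclobutylcarbonyl group removed, a drift towards a higher number in this assay is expected rather than a further fall. Compound 4 is therefore estimated at 0.08 ug/mL, between 0.015 ug/mL and 0.5 ug/mL, an expected step of a 6.2-fold higher number from compound 3 to compound 4 (0.79 log units; beyond the scatter).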

Compound 4, half-maximal effective concentration: 4.3 ug/mL
Compound 4: the middle estimate sits 54-fold (1.73 log units) below what was measured, and the stated range ends below it.
By their numbers in this assay, from the lowest: compound 3; then compound 2; then compounds 1 and 4 (each within the scatter of the next).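

In this assay, this nitrogen on an aromatic ring proves highly sensitive to what it carries: cyclohexylmethyl in place of cyclobutylcarbonyl gives a 330-fold higher number from compound 3 to compound 4 (2.52 log units; beyond the scatter), a much larger move than a 5.7-fold lower number from compound 1 to compound 2 (0.76 log units; beyond the scatter) at the other end of the shared core. The change removes the carbonyl and also replaces a four-membered ring with a six-membered one, so this single step cannot divide the effect between the two. No measurement available here explains its size. Still open, going by these compounds, is what cyclobutylmethyl would give on this nitrogen with the rest of compound 3 kept, which would separate loss of the carbonyl from the change of ring.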